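The source may report more compounds than this note shows. Statements on the series, on what has been measured and on what is new or still open speak of the compounds shown alone.

Two compounds sharing one core were tested in a functional assay on COLO 205 cells (Homo sapiens) for inhibition, read by sulforhodamine B assay, with a stated time of 48 h, tested at 100 uM; on this read-out lower numbers stand for less inhibition of growth and higher numbers for more inhibition of growth at the one concentration tested. Compound 1 `O=c1c(C(=S)Nc2ccccc2)coc2ccccc12` carries a thioamide arm, and in this assay compound 1 gives 71%. Compound 2 `O=c1c(C2N=C(c3ccccc3)SS2)coc2ccccc12` carries instead a sulfur-containing ring bearing a phenyl group, and in this assay compound 2 gives 18%, the lower of the two numbers, a gap to compound 1 that lies beyond the usual scatter. Compound 3 `O=c1c(C2N=C(c3ccccc3)SS2)coc2cc(Cl)ccc12` is compound 2 with a single change: chloro in place of hydrogen on an aromatic carbon. Among the compounds with values here, no measured pair shows this particular change, so its effect cannot be read from the numbers at hand. The change is expected to move the result only modestly and upward, with the step estimated at a number 10 percentage points higher from compound 2 to compound 3 (within the scatter), which may not clear the scatter. Compound 3 is therefore expected to give about 28% in this assay, within a range from 10% to 50%.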

Compound 3, percent growth inhibition at one concentration: 57%
Estimate against measurement, compound 3: 29 percentage points below; the measured number lies above the stated range.
By their numbers in this assay, from the lowest: compound 2; then compound 3; then compound 1.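

In this assay, chloro in place of hydrogen on an aromatic carbon gives a number 39 percentage points higher from compound 2 to compound 3 (beyond the scatter). Within the data shown here, this is the first sign that this place on the shared core, meta to a fused ring and para to a fused ring, matters for the read-out: one added chlorine atom is enough to produce a large step at the single concentration tested. Nothing measured here explains why the step is this large.

With only one replacement shown, it remains open whether the gain belongs to chloro itself or would also appear with another group at this carbon, such as fluoro, methoxy or an amine. On these data alone, it is also open whether chloro at this place would give a similar step on compound 1, which carries the thioamide arm instead of the sulfur-containing ring.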